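From ethoxy to bromo at an assay limit

The source may hold more compounds than are shown below. What is called first, only, known or untested is meant among the compounds shown, and "the series" means these compounds.

- Compound 1 `COc1ccc2c(c1)NC(=O)Nc1cnc(C#N)c(n1)OCCCCCO2`: > 10000 nM, a limit
- Compound 2 `CCOc1ccc2c(c1)NC(=O)Nc1cnc(C#N)c(n1)OCCCCCO2`: > 10000 nM, a limit

In a functional assay on NCI-H1299 cells (Homo sapiens), read by flow cytometry (a lower number here means that less compound is needed, a higher number that more compound is needed for the effect), compound 2 stands only at a limit, and no number is known for it. Compound 1 and compound 2 share one position, (the limit of > 10000 nM in this assay, at which 2 of the 2 values shown sit). For the measured compounds named here, the only measured step is a step that the two limits leave unreadable from compound 1 to compound 2, so it gives no size to carry forward.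

Compound 3 `N#Cc1ncc2nc1OCCCCCOc1ccc(Br)cc1NC(=O)N2` differs from compound 2 as follows: bromo in place of ethoxy on an aromatic carbon. This puts bromo in place of ethoxy on an aromatic carbon. Going by the values given here, no measured compound carries a bromo, and the data set no size for this change.

Compound 2 reads > 10000 nM, which is a limit, and this leaves room for a measurable value only on the side of less compound needed. A modest move in that direction is therefore expected, though this assay may again report only a limit. The expected change is an at least 2.0-fold lower number from compound 2 to compound 3 (0.30 log units; that floor lies within the scatter), an estimate with wide uncertainty. For compound 3 the estimated value is 5000 nM, with an expected range from 800 nM to 10000 nM.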

Compound 3, half-maximal effective concentration: 10000 nM
Estimate against measurement, compound 3: 2.0-fold (0.30 log units) below; measured number inside the range.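

In this assay compound 3 gives 10000 nM, the only actual number among the compounds shown and the only reading at this position that is not a limit. With bromo on the aromatic carbon that carries ethoxy in compound 2 and methoxy in compound 1, the assay therefore returns a number, though it gives no sign of activity clear of the limit. Bromo in place of ethoxy gives a number no higher from compound 2 to compound 3 (the limit leaves the size open), and bromo in place of methoxy gives a number no higher from compound 1 to compound 3 (the limit leaves the size open). Compound 1 and compound 2 stay as limits, so compound 3 stands alone as a measured value against them: the limit of > 10000 nM in this assay, at which 2 of the 3 values shown sit.

From the compounds shown here alone, whether another group on this aromatic carbon, such as chloro, an amine or a carboxylic acid, would bring the number clearly away from that limit remains open. Going by these compounds, it is also open whether a longer chain in place of the saturated chain of the shared core would shift the reading in this assay at all.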